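Cytotoxicity notes: a methoxy added to compound 2

A few compounds are considered here, and "the series" means these few. Any claim that something is new, unique, unknown or untested is made for them only; others in the source may bear on it.

In an ADME assay on HepG2 2.2.15 cells (Homo sapiens) for cytotoxicity, read by CCK-8 assay, with a stated time of 8 days (on this read-out lower numbers stand for higher toxicity in this test and higher numbers for lower toxicity in this test), compound 2 (`Cc1cccc(-c2cc(NC(=O)c3ccccc3O)c[nH]c2=O)c1`) gives 98800 nM, within the scatter of compound 1 (`COc1ccc(-c2cc(NC(=O)c3cccc(OC)c3O)c[nH]c2=O)cc1`) at 49200 nM. Among the measured compounds shown here, these two values are the only measurements so far. Compound 3 (`COc1cccc(C(=O)Nc2c[nH]c(=O)c(-c3cccc(C)c3)c2)c1O`) differs from compound 2 by methoxy in place of hydrogen on an aromatic carbon. For the measured compounds named here, no measured pair isolates this change, so no step beyond the scatter is expected, with at most a slight move toward lower numbers. The estimated change is a 1.4-fold lower number from compound 2 to compound 3 (0.15 log units; within the scatter). For compound 3 the expected value is 70000 nM, with an estimated range of 30000 nM to 160000 nM.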

Compound 3, half-maximal cytotoxic concentration: > 100000 nM
Compound 3: no number, only a limit; the forecaster's own chance of this, stated with the estimate: 15%; middle value at least 1.4-fold (0.15 log units) from the limit.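

In this assay compound 3 gives > 100000 nM, a limit of the assay and not a number. Methoxy in place of hydrogen ortho to a hydroxy group gives an at least 1.0-fold higher number from compound 2 to compound 3 (0.00 log units; that floor lies within the scatter), and 3-methylphenyl in place of 4-methoxyphenyl gives an at least 2.0-fold higher number from compound 1 to compound 3 (0.30 log units; that floor lies within the scatter), so neither change shows a move toward lower numbers. Both steps are floors within the scatter, and their true size stays unresolved, which rests on this reading: the limit of > 100000 nM in this assay, at which 1 of the 3 values shown sits.

As far as these compounds go, the actual value of compound 3 remains open. So does the effect of an amine or a carboxylic acid ortho to the hydroxy group.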